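This account rests on a few compounds, and the source may have more. Where it says the series, first, only, none or still open, it means among the compounds named here.

Measured so far in an assay on cells for displacement of a labelled ligand from adenosine receptor A1 (Homo sapiens), read by scintillation counting and radioligand binding, with a stated time of 60 min; on this read-out higher numbers stand for weaker inhibition and lower numbers for stronger inhibition:

compound 1 `CN1CCN(c2nc(-c3ccc(Cl)c(Cl)c3)nc3[nH]cnc23)CC1`: 631 nM
compound 2 `CN1CCN(c2nc(-c3cccc(Cl)c3)nc3[nH]cnc23)CC1`: 79.4 nM
compound 3 `Clc1ccc(-c2nc(N3CCCCC3)c3nc[nH]c3n2)cc1`: 126 nM

Compound 2 carries the lowest of the three numbers in this assay. Against compound 3 the gap is within the scatter, so the two cannot be ranked; against compound 1 the gap is beyond the scatter, and that step, a 7.9-fold lower number from compound 1 to compound 2 (0.90 log units; beyond the scatter), is the only one-place change measured in the series.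

Compound 4 `CN1CCN(c2nc(-c3cc(Cl)ccc3Cl)nc3[nH]cnc23)CC1` is the next entry. Relative to compound 2 the change is chloro in place of hydrogen on an aromatic carbon: the chloro enters ortho to a large group and para to a chloro group, so that 3-chlorophenyl becomes 2,5-dichlorophenyl.

Among the measured compounds shown here, the one step that bears on it runs the other way round: removing a chloro from the same six-membered ring gave a 7.9-fold lower number from compound 1 to compound 2 (0.90 log units; beyond the scatter), a modest drop in the number. Adding a chloro back, at a different place on that ring, is therefore expected to raise the number in this assay, though the position differs from that of compound 1 and the size cannot be copied directly. A step of a 3.1-fold higher number from compound 2 to compound 4 (0.50 log units; beyond the scatter) is expected, i.e. a moderate rise, not necessarily as large as the measured one.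

For compound 4 the expected value in this assay is 250 nM, with a range from 80 nM to 800 nM.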

Compound 4, inhibition constant: 2510 nM
The estimate for compound 4 lay 10-fold (1.00 log units) below the measured number, outside the stated range (above it).
By their numbers in this assay, from the lowest: compounds 2 and 3 (each within the scatter of the next); then compound 1; then compound 4.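

In this assay, among the compounds shown here, a chloro entering ortho to a large group and para to a chloro group gives a large step (a 32-fold higher number from compound 2 to compound 4 (1.50 log units; beyond the scatter)), whereas the only earlier chloro step was modest (a 7.9-fold lower number from compound 1 to compound 2 (0.90 log units; beyond the scatter)) and involved a different place on the ring. The count of chloro groups alone therefore does not set the number: 2,5-dichlorophenyl and 3,4-dichlorophenyl each carry two, yet the step between them lies beyond the scatter (a 4.0-fold higher number from compound 1 to compound 4 (0.60 log units; beyond the scatter)), so the arrangement on the ring matters in these compounds. Nothing at hand says what lies behind either step.

Still open, going by these compounds, is whether the large step belongs to chloro itself or to any group at that place, which a fluoro, a methyl, a methoxy or an amine ortho to the large group would test while the rest of compound 4 stays the same. Also open, on these data alone, is whether a chloro entering the aromatic ring of compound 3 at a comparable place would give a step of similar size on that different amine-bearing scaffold.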